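From Difluorophenyl to Methylphenyl on a Shared Core

The source may report more compounds than this note shows. Statements on the series, on what has been measured and on what is new or still open speak of the compounds shown alone.

Compound 1 `O=C(c1ccc2c(c1)OCCO2)C1CCN(Cc2coc(-c3ccoc3)n2)CC1` and compound 3 `O=C(c1ccc(F)c(F)c1)C1CCN(Cc2coc(-c3ccc(F)cc3)n2)CC1` were both examined in an ADME assay on HEK293 cells (Homo sapiens) for cytotoxicity, read by MTT assay, with a stated time of 36 h; a higher number here means a weaker inhibitor, a lower number a stronger inhibitor. In this assay compound 1 gives only the limit of > 150 ug/mL, which is a bound of the assay and not a measured number. Compound 2 `O=C(c1ccc2c(c1)OCCO2)C1CCN(Cc2csc(-c3ccc(Cl)cc3)n2)CC1` has no result in this assay, its entry reading "not determined" (no result reported). Compound 3 likewise gives only the limit of > 150 ug/mL in this assay, again a bound rather than a number. For the measured compounds named here, compound 3 therefore stands at the limit of > 150 ug/mL in this assay, at which 2 of the 3 values shown sit; no single-number value exists for it, and no measured step between two compounds is available.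

Compound 4 `Cc1ccc(C(=O)C2CCN(Cc3coc(-c4ccc(F)cc4)n3)CC2)cc1` differs from compound 3 in one place: 4-methylphenyl in place of 3,4-difluorophenyl on a carbonyl carbon. Going by the values given here, with no measured step to lean on, the change is expected to bring no shift beyond the usual scatter, so the step from compound 3 to compound 4 in this assay is estimated as a step that the limit leaves unreadable from compound 3 to compound 4. Compound 4 is accordingly expected to give about 160 ug/mL in this assay, within an estimated range from 80 ug/mL to 320 ug/mL, and most likely it will again be reported only as a limit.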

Compound 4, half-maximal inhibitory concentration: > 150 ug/mL
Compound 4 was reported as a limit; the forecaster's own chance of this, stated with the estimate: 75%; the middle value lies beyond the limit too.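

In this assay compound 4 gives > 150 ug/mL as a limit of the assay and not a number. For the compounds shown here, compound 3 is likewise reported only as a limit, so no step from compound 3 to compound 4 can be read: the limit of > 150 ug/mL in this assay, at which 3 of the 4 values shown sit. The compounds shown leave open whether 4-methylphenyl in place of 3,4-difluorophenyl changes cytotoxicity at all.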